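Fluoro for Hydrogen on the Benzyl Group of Compound 1

A few compounds are considered here, and "the series" means these few. Any claim that something is new, unique, unknown or untested is made for them only; others in the source may bear on it.

Measured compounds:
compound 1 `O=C(/C=C/c1ccc(OCc2cn(Cc3ccccc3)nn2)cc1)c1ccc(Br)cc1` gives 34%
compound 2 `O=C(/C=C/c1ccc(OCc2cn(Cc3ccccc3Br)nn2)cc1)c1ccc(Br)cc1` gives 44%
compound 3 `O=C(/C=C/c1ccc(OCc2cn(Cc3cccc(Br)c3)nn2)cc1)c1ccc(Br)cc1` gives 36%

All three were tested in a functional assay on MCF7 cells (Homo sapiens) for inhibition, read by MTT assay, with a stated time of 48 h, tested at 10 uM; on this read-out higher numbers stand for more inhibition of growth at the one concentration tested and lower numbers for less inhibition of growth. Compound 1 sits at the low end of the three numbers, but the gaps are small: a number 10 percentage points higher from compound 1 to compound 2 (within the scatter) and a number 2 percentage points higher from compound 1 to compound 3 (within the scatter), so no real difference between these compounds can be claimed. The pair compound 2 and compound 3 show the same picture, with a number 8 percentage points lower from compound 2 to compound 3 (within the scatter).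

Compound 4 `O=C(/C=C/c1ccc(OCc2cn(Cc3ccc(F)cc3)nn2)cc1)c1ccc(Br)cc1` is a new member of the series. Relative to compound 1 the change is fluoro in place of hydrogen on an aromatic carbon; the group sits on an aromatic carbon of a six-membered aromatic ring of carbon only, para to a large group, so the benzyl becomes a 4-fluorobenzyl.

Among the measured compounds shown here, the steps that bear on this are the two where a bromo took the place of a hydrogen on the same aromatic ring, from compound 1 to compound 2 and from compound 1 to compound 3. Both stayed within the scatter. A fluoro is a smaller halogen, and nothing measured here points in a different direction, so for compound 4 the expected step in this assay is a number 4 percentage points higher from compound 1 to compound 4 (within the scatter), that is, none beyond the scatter. The estimate for compound 4 is therefore 38%, with a range from 25% to 52%.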

Compound 4, percent growth inhibition at one concentration: 37%
Compound 4: middle estimate off by 1 percentage points, on the high side; low and high end bracket the measured number.
By their numbers in this assay, from the lowest: compounds 1, 3, 4 and 2 (each within the scatter of the next).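

In this assay, the step for the new compound is a number 3 percentage points higher from compound 1 to compound 4 (within the scatter), so fluoro in place of hydrogen at this place, para to a large group, joins the two bromo changes on the same benzyl ring as a swap that produces no real difference. The comparisons among the halogen-bearing compounds are just as flat, with a number 1 percentage points higher from compound 3 to compound 4 (within the scatter) and a number 7 percentage points lower from compound 2 to compound 4 (within the scatter), so across these four compounds neither the choice of fluoro or bromo nor the place on the ring separates one compound from another. Nothing available offers a reason for this flat picture.

All the changes shown are single halogen atoms on the benzyl ring, so it remains open whether a quite different group there, such as an amine or a carboxylic acid, would shift the number beyond the scatter. The bromophenyl group on the carbonyl side is also the same in all four compounds, which leaves open what would happen if a methoxy group or a plain hydrogen took the place of its bromo.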